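A swap from dimethylamino to pyridin-2-yl at a limit

A few compounds are considered here, and "the series" means these few. Any claim that something is new, unique, unknown or untested is made for them only; others in the source may bear on it.

Of the compounds shown here, three sharing one core have been tested in an ADME assay on MT4 cells (Homo sapiens) for cytotoxicity (a lower number here means that less compound is tolerated, a higher number that more compound is tolerated), and none of them gives a number. Compound 1 `COC(=O)N[C@H](C(=O)NN(CCC[C@@](O)(Cc1ccccc1)C(=O)N[C@H]1c2ccccc2C[C@H]1O)Cc1ccc(Br)cc1)C(C)(C)C` with bromo reads > 10000 nM as a limit of the assay. Compound 2 `COC(=O)N[C@H](C(=O)NN(CCC[C@@](O)(Cc1ccccc1)C(=O)N[C@H]1c2ccccc2C[C@H]1O)Cc1ccc(C#N)cc1)C(C)(C)C` with cyano reads > 10000 nM as a limit too. Compound 3 `COC(=O)N[C@H](C(=O)NN(CCC[C@@](O)(Cc1ccccc1)C(=O)N[C@H]1c2ccccc2C[C@H]1O)Cc1ccc(N(C)C)cc1)C(C)(C)C` with dimethylamino reads > 10000 nM as a limit as well, so it has no exact value of its own. The series as a whole offers only the limit of > 10000 nM in this assay, at which 3 of the 3 values shown sit, as a footing.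

Compound 4 `COC(=O)N[C@H](C(=O)NN(CCC[C@@](O)(Cc1ccccc1)C(=O)N[C@H]1c2ccccc2C[C@H]1O)Cc1ccc(-c2ccccn2)cc1)C(C)(C)C` carries pyridin-2-yl in place of dimethylamino on an aromatic carbon. Three measured swaps at this same place bear on the change, and none has a readable size: there is a step that the two limits leave unreadable from compound 1 to compound 2 and a step that the two limits leave unreadable from compound 1 to compound 3 and a step that the two limits leave unreadable from compound 2 to compound 3 as well. With no size to carry over, the expected change in this assay is none beyond the scatter, and the estimate takes a step that the limit leaves unreadable from compound 3 to compound 4 as its step. Compound 4 is estimated at 12000 nM with an expected range from 6000 nM to 25000 nM in that assay.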

Compound 4, half-maximal cytotoxic concentration: > 10000 nM
Compound 4 was reported as a limit (the forecaster's own chance of this, stated with the estimate: 80%); the middle value lies beyond the limit too.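

In this assay compound 4 gives > 10000 nM, again a limit of the assay. Among the compounds shown here, no step from compound 1, compound 2 or compound 3 to compound 4 can be read. The compounds shown leave open whether these groups differ at all, with every value at a limit: the limit of > 10000 nM in this assay, at which 4 of the 4 values shown sit.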